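This account rests on a few compounds, and the source may have more. Where it says the series, first, only, none or still open, it means among the compounds named here.

Compound 1 `COc1ccc(/C=C\c2cc(OC)c(OC)c(OC)c2)cc1OCc1ccc(CN2CCCC[C@@H]2C(=O)O)cc1` reaches only a limit in a functional assay on B16-F10 cells (Mus musculus) for antiproliferative activity, read by CCK-8 assay, with a stated time of 48 h (on this read-out higher numbers stand for weaker inhibition and lower numbers for stronger inhibition), namely > 10000 nM. Among the compounds with values here, compound 2 `COc1ccc(/C=C\c2cc(OC)c(OC)c(OC)c2)cc1OCc1ccc(CNCCO)cc1` gives 6600 nM, the only actual number so far in this assay. Compound 3 `COc1ccc(/C=C\c2cc(OC)c(OC)c(OC)c2)cc1OCc1ccc(CO)cc1` carries one change on a saturated chain carbon bound to an aromatic carbon: hydroxy in place of (2-hydroxyethyl)amino (hydroxy in place of (2-hydroxyethyl)amino on a saturated chain carbon bound to an aromatic carbon). Within the data shown here, the sole measured step, an at least 1.5-fold lower number from compound 1 to compound 2 (0.18 log units; that floor lies within the scatter), changes the group at the same kind of carbon, but its floor lies within the scatter and it rests on (the limit of > 10000 nM in this assay, at which 1 of the 2 values shown sits). It offers weak guidance, so only a modest lowering is expected, estimated as a 2.6-fold lower number from compound 2 to compound 3 (0.42 log units; beyond the scatter). For compound 3 the estimated value is 2500 nM, with an expected range of 300 nM to 10000 nM.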

Compound 3, half-maximal inhibitory concentration: 6600 nM
Estimate against measurement, compound 3: 2.6-fold (0.42 log units) below; low and high end bracket the measured number.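

In this assay, hydroxy in place of (2-hydroxyethyl)amino on a saturated chain carbon bound to an aromatic carbon gives no change at the digits printed from compound 2 to compound 3 (within the scatter), so this position shows no readable difference between these two groups. The comparison with 2-carboxypiperidin-1-yl, an at least 1.5-fold lower number from compound 1 to compound 3 (0.18 log units; that floor lies within the scatter), gives only a floor, since one end of it is a limit: the limit of > 10000 nM in this assay, at which 1 of the 3 values shown sits.

On these data alone, whether a methoxy group, a primary amine or a longer chain ending in a carboxylic acid on this carbon would shift the number remains open. So does how far the true value of the piperidine compound lies from the other two.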